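This account rests on a few compounds, and the source may have more. Where it says the series, first, only, none or still open, it means among the compounds named here.

Compound 1 `Fc1ccc(-c2cn3nc(Cc4ccc(Cl)cc4)sc3n2)cc1` — in a functional assay on HeLa cells (Homo sapiens) for cytotoxicity, with a stated time of 72 h (a lower number here means a stronger inhibitor, a higher number a weaker inhibitor), compound 1 gives > 250000 nM
Compound 2 `O=[N+]([O-])c1ccc(-c2cn3nc(Cc4ccc(Cl)cc4)sc3n2)cc1` — in this assay compound 2 gives > 250000 nM

Both figures are limits of the assay, not numbers. For compound 1 the value in this assay is only a limit. For compound 2 the value is likewise only a limit. Among the compounds with values here, the single measured step, a step that the two limits leave unreadable from compound 1 to compound 2, nitro in place of fluoro on an aromatic carbon, cannot be read because of the limit of > 250000 nM in this assay, at which 2 of the 2 values shown sit. Compound 1 therefore stands only at the limit, with no readable step around it.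

Compound 3 `N#CSc1c(-c2ccc(F)cc2)nc2sc(Cc3ccc(Cl)cc3)nn12` differs from compound 1 by cyanosulfanyl in place of hydrogen on an aromatic carbon. Within the data shown here, no measured step touches this position or this group, so no step in this assay can be read as bearing on it; only the shared limit of the two measured compounds is available as a guide. Compound 3 is expected to sit at the same limit, with an estimated value of 250000 nM, between 60000 nM and 1000000 nM. The expected step is a number no higher from compound 1 to compound 3 (the limit leaves the size open).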

Compound 3, half-maximal inhibitory concentration: 20000 nM
Compound 3: middle estimate off by 13-fold (1.10 log units), on the high side; the measured number lies below the stated range.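

With compound 3, a change first moves the number in this assay off the limit: cyanosulfanyl in place of hydrogen on an aromatic carbon gives an at least 12-fold lower number from compound 1 to compound 3 (1.09 log units; beyond the scatter). The earlier pair could not show this, since the step between compound 1 and compound 2, made on the 4-fluorophenyl group, cannot be read, whereas this carbon, next to the ring atom that bears that group, is now a position where a change registers. For compound 1 the value > 250000 nM is a limit, so the full size of the step stays unfixed.

On these data alone, what a methylsulfanyl group, or a nitrile set directly on this carbon, would give remains open. So does whether cyanosulfanyl at this position would lower the number equally with a nitro group in place of the fluoro.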